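Chloro in place of hydrogen on a shared core

The source may hold more compounds than are shown below. What is called first, only, known or untested is meant among the compounds shown, and "the series" means these compounds.

Compound 1 `COc1ccccc1-c1n[nH]cc1N1CCNCC1` gives in an assay on isolated protein for binding affinity to 5-hydroxytryptamine receptor 4 (Homo sapiens) (on this read-out lower numbers stand for stronger inhibition and higher numbers for weaker inhibition), only a limit, > 10000 nM.
Compound 2 `COc1ccc(-c2n[nH]cc2N2CCNCC2)cc1` gives in this assay only a limit, > 10000 nM.
Compound 3 `c1ccc(-c2n[nH]cc2N2CCNCC2)cc1` gives in this assay only a limit, > 10000 nM.

Compound 3 therefore stands at the edge of what this assay reports, and it does not stand alone there: the limit of > 10000 nM in this assay, at which 3 of the 3 values shown sit. Compound 4 `Clc1ccccc1-c1n[nH]cc1N1CCNCC1` differs from compound 3 by chloro in place of hydrogen on an aromatic carbon, the chloro sitting on an aromatic carbon of a six-membered aromatic ring of carbon only, ortho to a large group. Going by the values given here, two measured steps concern a change at a carbon of this same ring, the removal of a methoxy group: a step that the two limits leave unreadable from compound 1 to compound 3 and a step that the two limits leave unreadable from compound 2 to compound 3. Neither step can be read in size, because each of its ends is a limit, so they give no direction and no magnitude for a substituent at this position. Compound 4 is consequently expected to remain close to the limit as well, and the estimate for compound 4 in this assay is 20000 nM, with a range from 5000 nM to 80000 nM. The estimated step that the limit leaves unreadable from compound 3 to compound 4 is not expected to exceed the usual scatter.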

Compound 4, inhibition constant: > 10000 nM
Compound 4: no number, only a limit; the forecaster's own chance of this, stated with the estimate: 85%; the middle value lies beyond the limit too.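

Compound 4 gives only a limit in this assay, as do compound 1 and compound 3, so neither new step, from compound 3 or from compound 1 to compound 4, can be read in size: the limit of > 10000 nM in this assay, at which 4 of the 4 values shown sit.

The compounds shown leave open whether any change on this shared core gives a measurable value in this assay.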